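The source may hold more compounds than are shown below. What is called first, only, known or untested is meant among the compounds shown, and "the series" means these compounds.

Measured compounds:

Compound 1, `Clc1ccc2c(NCCNc3nccc(Cl)n3)ccnc2c1`: 900 nM
Compound 2, `Clc1ccc2c(NCCNc3ccnc(Cl)n3)ccnc2c1`: 680 nM
Compound 3, `Clc1ccc2c(NCCCCCCCCNc3nccc(Cl)n3)ccnc2c1`: 90 nM

The study measures three compounds in a physicochemical assay for solubility, read by HPLC, in phosphate buffer, with a stated time of 24 h, at pH 7.4; a lower number here means a less soluble compound, a higher number a more soluble compound. Compound 1 and compound 2 share a core and differ in a single place: 2-chloropyrimidin-4-yl in place of 4-chloropyrimidin-2-yl on an amine nitrogen. The step that this change made in this assay is a 1.3-fold lower number from compound 1 to compound 2 (0.12 log units; within the scatter), so the two values are read as equal within the scatter of the method.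

Compound 3 carries a longer chain than compound 1; the difference between the two cores is not broken down here. In this assay compound 3 gives the lowest of the three numbers, and its gap to compound 2 and to compound 1 lies beyond the scatter in each case.

Compound 4, `Clc1ccc2c(NCCCCCCCCNc3ccnc(Cl)n3)ccnc2c1`, is not yet measured. It stands to compound 3 as compound 2 stands to compound 1, with the same change at the same kind of place: 2-chloropyrimidin-4-yl in place of 4-chloropyrimidin-2-yl on an amine nitrogen. Among the measured compounds shown here, because the earlier step of this change was a 1.3-fold lower number from compound 1 to compound 2 (0.12 log units; within the scatter), the step in this assay is expected to be small again, a 1.3-fold lower number from compound 3 to compound 4 (0.11 log units; within the scatter), resting on the single measured pair and on the value of compound 3, 90 nM. Compound 4 is therefore estimated at 70 nM, within a range from 30 nM to 170 nM.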

Compound 4, solubility: 80 nM
Compound 4: the middle estimate sits 1.1-fold (0.06 log units) below what was measured, within the range that was stated.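

In this assay, placing 2-chloropyrimidin-4-yl where 4-chloropyrimidin-2-yl stood on an amine nitrogen now gives a 1.1-fold lower number from compound 3 to compound 4 (0.05 log units; within the scatter) and sits alongside the earlier 1.3-fold lower number from compound 1 to compound 2 (0.12 log units; within the scatter) in the same assay, so the change stays within the scatter on both of the cores shown. This suggests that, for these two pairs, the near-equal values seen on the first core carried over to the second, but two pairs show no rule for the series, and with both steps within the scatter they cannot show whether the change has a small real effect or none, or in which direction any such effect would run. No measurement is offered that bears on why the two arrangements of the chloropyrimidine read alike here.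

The compounds shown leave open whether the same change would stay within the scatter on a core carrying a chain of another length, or a chain bearing an added amine or carboxylic acid. They also leave open whether it would do so if a fluorine atom or a methoxy group stood in place of the chlorine on the pyrimidine, since every pair shown keeps that chlorine and the same remaining core.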